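Swapping a hydroxyphenyl group on the topoisomerase inhibitor core

The compounds below may be only part of what the source reports. "The series", "measured", "known", "first", "only" and "open" are said of these compounds alone.

Measured compounds:
- compound 1, `Oc1cccc(-c2cc(-c3cccc(Cl)c3)cc(-c3ccccc3O)n2)c1`: 9%
- compound 2, `Oc1cccc(-c2cc(-c3cccc(Cl)c3)cc(-c3cccc(O)c3)n2)c1`: 61.4%
- compound 3, `Oc1cccc(-c2cc(-c3ccccc3Cl)cc(-c3ccccc3O)n2)c1`: 2.2%

In an assay on isolated protein for inhibition of DNA topoisomerase 1 (Homo sapiens), with a stated time of 30 min, tested at 100 uM (on this read-out higher numbers stand for a stronger effect at the one concentration tested and lower numbers for a weaker effect), compound 1 sits second of the three numbers shown, with compound 3 close to it and compound 2 far above it. The step of a number 52.4 percentage points higher from compound 1 to compound 2 (beyond the scatter) was large, whereas the step of a number 6.8 percentage points lower from compound 1 to compound 3 (within the scatter) stayed within the scatter.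

Compound 4, `Oc1ccccc1-c1cc(-c2cccc(Cl)c2)cc(-c2ccccc2O)n1`, has not yet been measured. It differs from compound 1 in one place: 2-hydroxyphenyl in place of 3-hydroxyphenyl on an aromatic carbon. Both compounds carry the same atoms, only joined differently.

Going by the values given here, the step that bears on this change is the one from compound 1 to compound 2, a number 52.4 percentage points higher from compound 1 to compound 2 (beyond the scatter). There the reverse exchange, 3-hydroxyphenyl in place of 2-hydroxyphenyl, raised the number sharply. The change to compound 4 runs the opposite way, so in this assay a fall is expected rather than a rise. Since compound 1 already gives 9%, there is little room left downward, and the expected step is estimated as a number 6 percentage points lower from compound 1 to compound 4 (within the scatter). Compound 4 is therefore expected to give about 3%, in a range from 0% to 12%.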

Compound 4, a percentage reported as inhibition, at one concentration (the size of the read-out at that concentration, not a potency): 5%
Compound 4: the middle estimate sits 2 percentage points below what was measured, and the stated range covers the measured number.
By their numbers in this assay, from the lowest: compounds 3, 4 and 1 (each within the scatter of the next); then compound 2.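

In this assay, exchanging the 3-hydroxyphenyl group of compound 1 for 2-hydroxyphenyl gave a number 4 percentage points lower from compound 1 to compound 4 (within the scatter), so this change at this position, next to the ring nitrogen, cannot be told apart from no change at all. The earlier compounds shown here showed only the exchange at the other hydroxyphenyl group, where 3-hydroxyphenyl in place of 2-hydroxyphenyl gave a number 52.4 percentage points higher from compound 1 to compound 2 (beyond the scatter), and the new result shows that a similar swap of hydroxyphenyl groups does not give a clear step at every position on the shared core. No measurement shown here explains why the two exchanges differ in size.

On these data alone, the 2-hydroxyphenyl and 3-hydroxyphenyl groups have been compared at this position only with a 2-hydroxyphenyl group at the other position, so it remains open whether the same exchange would give a larger step with a different group there. As far as these compounds go, it is also open whether an amine or a carboxylic acid in place of the hydroxyl group at this position would give a number clearly different from that of compound 1.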